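Swapping the aromatic methyl for chloro in compound 2

A few compounds are considered here, and "the series" means these few. Any claim that something is new, unique, unknown or untested is made for them only; others in the source may bear on it.

Compound 2, with the structure `COc1ccccc1N1CCN(CC2=NS(=O)(=O)c3ccc(C)cc3N2)CC1`, is the lower of the two measured compounds: in a functional assay on thoracic aorta for antagonist activity at Alpha-1D adrenergic receptor (Rattus norvegicus) (a lower number here means a less potent compound, a higher number a more potent compound, by a factor of ten per unit of this negative logarithm), compound 2 gives 5.5. Among the measured compounds shown here, its partner compound 1, `COc1ccccc1N1CCN(CC2=NS(=O)(=O)c3ccccc3N2)CC1`, gives 7.59 in this assay, and the only measured step, a number 2.09 log units lower from compound 1 to compound 2 (beyond the scatter), is a methyl placed on an aromatic carbon of the shared core. Compound 3, `COc1ccccc1N1CCN(CC2=NS(=O)(=O)c3ccc(Cl)cc3N2)CC1`, keeps that aromatic carbon substituted but carries chloro in place of methyl on an aromatic carbon. No measured pair shows what replacing one single-atom substituent by another at this position does, so the one step shown offers only indirect guidance: it tells that this position is sensitive, and that a bare hydrogen there gives the higher number. Given that compound 2 already sits far below compound 1, the estimated step of a number 0.40 log units higher from compound 2 to compound 3 (beyond the scatter) is small and uncertain, with some chance of partial recovery toward compound 1. The estimate for compound 3 in this assay is 5.9, expected within 5 to 7.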

Compound 3, negative logarithm of the antagonist equilibrium constant: 7.75
The estimate for compound 3 lay 1.85 log units below the measured number; measured number above the stated range.
By their numbers in this assay, from the lowest: compound 2; then compounds 1 and 3 (each within the scatter of the next).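

In this assay, the earlier step had suggested that this aromatic carbon resists substitution, yet exchanging one heavy atom for another gives a number 2.25 log units higher from compound 2 to compound 3 (beyond the scatter), so the low number belongs to methyl and not to every substituent there. Chloro also gives a number 0.16 log units higher from compound 1 to compound 3 (within the scatter), which means that among these three compounds a substituent at this place can leave the number level with the unsubstituted compound 1, and only the methyl of compound 2 stands apart. Nothing available here accounts for the sharp difference between methyl and chloro.

The compounds shown leave open whether fluoro, bromo or methoxy on this same carbon would group with chloro or with methyl, and whether an ethyl group would track methyl. They also leave open whether chloro would give a similar number on the other aromatic carbons of the shared core.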